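Extending a methyl to propyl on an aromatic amine scaffold

The compounds below may be only part of what the source reports. "The series", "measured", "known", "first", "only" and "open" are said of these compounds alone.

Of the compounds shown here, two have been tested in an assay on CHO cells for agonist activity at Alpha-2B adrenergic receptor (Homo sapiens), with a stated time of 240 min; on this read-out higher numbers stand for an effect only at larger amounts of compound and lower numbers for an effect already at smaller amounts. Compound 1 `C=CCc1ccccc1NCC1=NCCN1` carries an allyl chain on the aromatic ring and gives 2510 nM. Compound 2 `Cc1ccccc1NCC1=NCCN1` carries a methyl in its place and gives 3160 nM. Within the data shown here, the only step between them, a 1.3-fold higher number from compound 1 to compound 2 (0.10 log units; within the scatter), shows that trading the vinyl end of the allyl for a hydrogen changed nothing that can be told from the scatter of the method; compound 2 holds the higher of the two numbers only nominally.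

Compound 3 `CCCc1ccccc1NCC1=NCCN1` now takes the step the other way, with ethyl in place of hydrogen on a saturated chain carbon bound to an aromatic carbon, giving a propyl chain where compound 2 had a methyl. Among the measured compounds shown here, the one relevant comparison is that step from compound 1 to compound 2, which lay within the scatter, so no shift beyond the scatter is expected, and the value for compound 3 is estimated at 2500 nM, between 1000 nM and 6300 nM, corresponding to an expected step of a 1.3-fold lower number from compound 2 to compound 3 (0.10 log units; within the scatter).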

Compound 3, half-maximal effective concentration: 4570 nM
Compound 3: the middle estimate sits 1.8-fold (0.26 log units) below what was measured, within the range that was stated.
By their numbers in this assay, from the lowest: compounds 1, 2 and 3 (each within the scatter of the next).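

In this assay, this place on the shared core has now carried three different chains, and the numbers do not separate them: the step for methyl to propyl is a 1.4-fold higher number from compound 2 to compound 3 (0.16 log units; within the scatter), and the step for ethyl in place of vinyl is a 1.8-fold higher number from compound 1 to compound 3 (0.26 log units; within the scatter). The earlier pair showed only that removing the vinyl end of the allyl chain made no readable difference, whereas these steps add that a fully saturated propyl chain also reads the same as both the methyl and the allyl chain. Nothing measured here accounts for this flat result.

All three chains consist only of carbon and hydrogen, so a longer chain such as hexyl, or a chain ending in an amine or a carboxylic acid, remains an open case. As far as these compounds go, whether any group at this place can move the number beyond the scatter also stays open.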